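Replacing phenyl with thiophen-3-yl in compound 2

The source may report more compounds than this note shows. Statements on the series, on what has been measured and on what is new or still open speak of the compounds shown alone.

Measured in an ADME assay on BJ cells (Homo sapiens) for cytotoxicity, read by MTT assay, with a stated time of 72 h; on this read-out lower numbers stand for higher toxicity in this test and higher numbers for lower toxicity in this test:
Compound 1 `OC[C@H]1O[C@@H](n2cc(Cl)c3c(-c4ccccc4)ncnc32)[C@H](O)[C@@H]1O` gives 44500 nM
Compound 2 `CCCCCCCCCCCCCCCCCCOP(=O)(O)OC[C@H]1O[C@@H](n2ccc3c(-c4ccccc4)ncnc32)[C@H](O)[C@@H]1O` gives > 50000 nM

Compound 2 has no number in this assay, only the limit > 50000 nM.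

Compound 3 `CCCCCCCCCCCCCCCCCCOP(=O)(O)OC[C@H]1O[C@@H](n2ccc3c(-c4ccsc4)ncnc32)[C@H](O)[C@@H]1O` carries thiophen-3-yl in place of phenyl on an aromatic carbon of compound 2 (thiophen-3-yl in place of phenyl on an aromatic carbon). Going by the values given here, no measured pair of compounds shows what such a change does, so no direction is favoured and nothing beyond the usual scatter is expected in this assay. The expected step is a number no higher from compound 2 to compound 3 (the limit leaves the size open). For compound 3 the estimated value is 50000 nM, with an expected range from 25000 nM to 100000 nM.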

Compound 3, half-maximal cytotoxic concentration: > 50000 nM
Compound 3 gave a limit, no number; the forecaster's own chance of this, stated with the estimate: 75%; the middle value lies on the limit itself.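

Compound 3, like compound 2, gave only a limit in this assay, so no step between compound 2 and compound 3 can be read: the limit of > 50000 nM in this assay, at which 2 of the 3 values shown sit.

From the compounds shown here alone, whether thiophen-3-yl in place of phenyl changes this read-out at all remains open.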